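Two Benzyl-Substituted Nucleosides and a Dihydroxyphenyl Cousin

This account rests on a few compounds, and the source may have more. Where it says the series, first, only, none or still open, it means among the compounds named here.

Compound 1, `COc1cccc(CNc2ncnc3c2ncn3[C@@H]2O[C@H](CO)[C@@H](O)[C@H]2O)c1`, in a functional assay on G-361 cells (Homo sapiens) for antiproliferative activity, with a stated time of 72 h; on this read-out lower numbers stand for stronger inhibition and higher numbers for weaker inhibition: "not determined" (no result reported).
Compound 2, `OC[C@H]1O[C@@H](n2cnc3c(NCc4cc(F)cc(F)c4)ncnc32)C(O)C1O`, in this assay: > 166000 nM, which is a limit of the assay and not a number.

Compound 1 stands without a single number in this assay; the only reading beside it is the limit of compound 2, shown in the limit of > 166000 nM in this assay, at which 1 of the 2 values shown sits. Compound 3, `OC[C@H]1O[C@@H](n2cnc3c(NCc4cccc(O)c4O)ncnc32)[C@H](O)[C@@H]1O`, differs from compound 1 in one place: 2,3-dihydroxyphenyl in place of 3-methoxyphenyl on a saturated chain carbon bound to a nitrogen on an aromatic ring. Going by the values given here, with no measured step to lean on, the step in this assay for this change is expected to be small, with no clear direction beyond the scatter. Compound 3 is therefore estimated at 100000 nM, expected to fall between 20000 nM and 500000 nM.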

Compound 3, half-maximal inhibitory concentration: 16900 nM
Compound 3: the middle estimate sits 5.9-fold (0.77 log units) above what was measured; the measured number lies below the stated range.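

Going by these compounds alone, compound 1 has no number in this assay, so no step from it to compound 3 can be read. The compounds shown leave open how far the change from 3-methoxybenzyl to 2,3-dihydroxybenzyl shifts activity in this assay.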